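A few compounds are considered here, and "the series" means these few. Any claim that something is new, unique, unknown or untested is made for them only; others in the source may bear on it.

Measured so far: compound 1 `CN1C/C(=C\c2ccccc2)C(=O)[C@]2(C1)[C@@H](c1ccccc1)CN(C)[C@@]21C(=O)Nc2ccccc21` at 73.3%; compound 2 `CN1C/C(=C\c2ccccc2)C(=O)[C@]2(C1)[C@@H](c1ccccc1)CN(C)[C@@]21C(=O)N(C)c2ccccc21` at 70.7%.

Compound 1 holds the highest of the two numbers in a functional assay on the whole organism (strain Wister albino) for inhibition, with Rattus norvegicus as the target, read by paw edema, with stated times of 1 h and 2 h, at a dose of 50 mg/kg by the intraperitoneal route (on this read-out higher numbers stand for more inhibition at the one dose given (going by the name of the read-out) and lower numbers for less inhibition), though the step of a number 2.6 percentage points lower from compound 1 to compound 2 (within the scatter) lies within the scatter, so the two measured compounds cannot be told apart. Compound 3 `COc1ccc(/C=C2\CN(C)C[C@@]3(C2=O)[C@@H](c2ccccc2)CN(C)[C@@]32C(=O)Nc3ccccc32)cc1` is not yet measured. It differs from compound 1 by methoxy in place of hydrogen on an aromatic carbon. For the measured compounds named here, the only measured step, methyl in place of hydrogen on an amide-type nitrogen in a ring, touches a different part of the shared core and says nothing about the aromatic carbon changed here. Going by the values given here, no measured step bears directly on this change, so the expectation rests on compound 1 alone, and no step beyond the scatter is expected: the estimated step is a number 1.3 percentage points lower from compound 1 to compound 3 (within the scatter). The expected value for compound 3 in this assay is therefore 72%, within 58% to 84%.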

Compound 3, a percentage reported as inhibition, in the whole organism at one dose (the size of the read-out at that dose, not a potency): 76.4%
Compound 3: the middle estimate sits 4.4 percentage points below what was measured; the measured number falls inside the stated range.
By their numbers in this assay, from the lowest: compounds 2, 1 and 3 (each within the scatter of the next).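

Methoxy in place of hydrogen on an aromatic carbon, para to a large group, is the only change shown at this ring, with a number 3.1 percentage points higher from compound 1 to compound 3 (within the scatter) in this assay as its result. The earlier pair spoke only to the amide-type nitrogen, whereas this pair shows that, at the one dose given, the read-out does not separate phenyl from 4-methoxyphenyl on the core of compound 1. No measurement on hand accounts for this result.

From the compounds shown here alone, whether an amine, a carboxylic acid or a longer chain such as butoxy at this carbon would give a step beyond the scatter remains open, as does the effect of methoxy on another carbon of the same ring. Also open, going by these compounds, is how methoxy at this position would read together with methyl on the amide-type nitrogen.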